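The source may hold more compounds than are shown below. What is called first, only, known or untested is meant among the compounds shown, and "the series" means these compounds.

Measured in a functional assay on PC-3 cells (Homo sapiens) for antiproliferative activity, read by MTT assay, with a stated time of 72 h; on this read-out higher numbers stand for weaker inhibition and lower numbers for stronger inhibition:
- compound 1 `CCN(CC)CCNC(=O)c1ccc(C(CC)(CC)c2ccc(OCC(O)C(C)(C)C)c(C)c2)n1CC` gives 2800 nM
- compound 2 `CCn1c(C(=O)NCc2ccc(OC)cc2)ccc1C(CC)(CC)c1ccc(C#CC(O)(CC)CC)c(C)c1` gives > 50000 nM (a limit of the assay)
- compound 3 `CCN(CC)CCNC(=O)c1cc(C(CC)(CC)c2ccc(C#CC(O)(CC)CC)c(C)c2)cn1CC` gives 5350 nM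

Within the data shown here, compound 3 and compound 1 lie within the scatter of each other, so compound 3 sits with the only other compound that gives a number. Compound 4 `CCn1cc(C(CC)(CC)c2ccc(C#CC(O)(CC)CC)c(C)c2)cc1C(=O)N[C@@H](C(=O)O)C(C)C` differs from compound 3 by 1-carboxy-2-methylpropyl in place of 2-(diethylamino)ethyl on an amide-type nitrogen. Compound 2 also lacks 2-(diethylamino)ethyl, and its > 50000 nM is a limit. A rise beyond the scatter in this assay, towards weaker inhibition, is therefore expected, with an estimated 4.7-fold higher number from compound 3 to compound 4 (0.67 log units; beyond the scatter). For compound 4 the estimated value is 25000 nM, with an expected range from 8000 nM to 50000 nM.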

Compound 4, half-maximal inhibitory concentration: 10300 nM
Beside the measured number, compound 4's estimate is 2.4-fold (0.39 log units) above it; measured number inside the range.
By their numbers in this assay, from the lowest: compounds 1, 3 and 4 (each within the scatter of the next, the first and the last beyond it). At a limit, above all of these: compound 2.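

In this assay, the step at the amide-type nitrogen is small: 1-carboxy-2-methylpropyl in place of 2-(diethylamino)ethyl gives a 1.9-fold higher number from compound 3 to compound 4 (0.28 log units; within the scatter). On this core, then, a measured number at this position does not depend on keeping 2-(diethylamino)ethyl. Compound 4 gives a number rather than a limit, and the limit remains with compound 2 alone: the limit of > 50000 nM in this assay, at which 1 of the 4 values shown sits.

This single pair does not show how far the position tolerates other groups, such as a carboxymethyl or a 2-(dimethylamino)ethyl chain. On these data alone, whether the defined stereocentre of 1-carboxy-2-methylpropyl matters also stays open.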